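Isopropyl on the aromatic nitrogen of the shared core

The source may report more compounds than this note shows. Statements on the series, on what has been measured and on what is new or still open speak of the compounds shown alone.

Measured so far in a functional assay on BT-474 cells (Homo sapiens) for inhibition, read by MTT assay, with a stated time of 5 days (a lower number here means a stronger inhibitor, a higher number a weaker inhibitor), are:
- compound 1 `Cc1cc(Nc2nc(NCc3ccccc3F)nc3[nH]ncc23)n[nH]1` at 13200 nM 
- compound 2 `Cc1cc(Nc2nc(NCc3ccc(Cl)cc3)nc3[nH]ncc23)n[nH]1` at 11700 nM 

Compound 2 stands at 11700 nM and so lies within the scatter of compound 1. The next compound is compound 3 `Cc1cc(Nc2nc(NCc3ccc(Cl)cc3)nc3c2cnn3C(C)C)n[nH]1`, with isopropyl in place of hydrogen on an aromatic nitrogen. For the measured compounds named here, the only measured step is a 1.1-fold lower number from compound 1 to compound 2 (0.05 log units; within the scatter) and it concerns the aryl group, not the aromatic nitrogen. Going by the values given here, it therefore gives no direct guide, and no measured step shows what a change at this nitrogen does. A modest move to a lower number is expected, though with little support. The estimated change is a 1.7-fold lower number from compound 2 to compound 3 (0.22 log units; within the scatter) and a step within the scatter would not surprise. For compound 3 the expected value is 7000 nM with an estimated range from 2000 nM to 20000 nM in this assay for now.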

Compound 3, half-maximal inhibitory concentration: 13000 nM
For compound 3 the middle estimate is 1.9-fold (0.27 log units) below the measured one; the measured number falls inside the stated range.
By their numbers in this assay, from the lowest: compounds 2, 3 and 1 (each within the scatter of the next).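

In this assay, for the compounds shown here, isopropyl in place of hydrogen on an aromatic nitrogen gives a 1.1-fold higher number from compound 2 to compound 3 (0.05 log units; within the scatter), the first reading at this position of the shared core. The hydrogen on this nitrogen can therefore be replaced by isopropyl without a step beyond the scatter, so this position, like the aryl group in a 1.1-fold lower number from compound 1 to compound 2 (0.05 log units; within the scatter), has not yet separated any compounds in the series. Nothing available here accounts for this result.

Going by these compounds alone, only one group has been read on this nitrogen, so it remains open whether a methyl, a longer chain or a chain carrying an amine or a carboxylic acid would give a step beyond the scatter. Going by these compounds, it also remains open whether isopropyl would give a similar step alongside the 2-fluorophenyl group of compound 1.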